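Isopropyl to propyl on the sulfonamide nitrogen of compound 2

The source may hold more compounds than are shown below. What is called first, only, known or untested is meant among the compounds shown, and "the series" means these compounds.

Three members of the series have been run in a functional assay on BXPC-3 cells (Homo sapiens) for inhibition, read by MTT assay, with a stated time of 7 days; on this read-out higher numbers stand for weaker inhibition and lower numbers for stronger inhibition. Compound 1 `CCOC(=O)[C@@H]1C[C@H](O)CN(S(=O)(=O)c2ccc(S(=O)(=O)N(CC)CC)cc2)C1` gives 3300 nM, compound 2 `CCOC(=O)[C@@H]1CCCN(S(=O)(=O)c2ccc(S(=O)(=O)N(CC)C(C)C)cc2)C1` gives 1600 nM, and compound 3 `CCN(CC)S(=O)(=O)c1ccc(S(=O)(=O)N2CCC[C@@H](C(=O)NC)C2)cc1` gives 13800 nM. Compound 2 stands lowest of the three; its gaps to compound 1 and to compound 3 both lie beyond the scatter, with compound 3 the furthest away. Among the measured compounds shown here, no pair among the three differs in one place only, so none of these gaps can be tied to a single change.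

Compound 4 `CCCN(CC)S(=O)(=O)c1ccc(S(=O)(=O)N2CCC[C@@H](C(=O)OCC)C2)cc1` is the next candidate and differs from compound 2 as follows: propyl in place of isopropyl on a sulfonamide nitrogen. The change keeps the shared core of compound 2 and its ethyl ester untouched. Nothing measured in this series isolates a change of this kind, so the step from compound 2 is expected to be small, in no firm direction, and likely within the scatter; the estimate is a 1.3-fold higher number from compound 2 to compound 4 (0.10 log units; within the scatter). Compound 4 is therefore expected to give about 2000 nM, within 900 nM to 4500 nM.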

Compound 4, half-maximal inhibitory concentration: 300 nM
The estimate for compound 4 lay 6.7-fold (0.82 log units) above the measured number, and the stated range ends above it.
By their numbers in this assay, from the lowest: compound 4; then compound 2; then compound 1; then compound 3.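

Among the compounds shown here, the step on this sulfonamide nitrogen is the only single change that can be read so far: in this assay, propyl in place of isopropyl gives a 5.3-fold lower number from compound 2 to compound 4 (0.73 log units; beyond the scatter). The two compounds have the same atoms, joined differently, so at this position the way three carbons are connected is enough to move the number beyond the scatter. No measurement shown offers an explanation for the step.

As far as these compounds go, whether a longer chain such as butyl, or a ring such as cyclopropyl, on this nitrogen would extend or reverse the step remains open. Also open, from the compounds shown here alone, is whether propyl gives a similar step when the ethyl ester is replaced by a carboxylic acid, or when it is paired with the methyl amide of compound 3.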